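Swapping a methoxy for a cyclic ether on a shared core

The source may report more compounds than this note shows. Statements on the series, on what has been measured and on what is new or still open speak of the compounds shown alone.

Of the compounds shown here, three sharing one core have been tested in a functional assay on MCF7 cells (Homo sapiens) for antiproliferative activity, read by MTT assay, with a stated time of 72 h; a higher number here means a weaker inhibitor, a lower number a stronger inhibitor. Compound 1 `COc1cc2ncnc(N3CCc4ccccc43)c2cc1NC(=O)/C=C/C(C)C` gives 6780 nM. Compound 2 `CC(C)/C=C/C(=O)Nc1cc2c(N3CCc4ccccc43)ncnc2cc1O[C@@H]1CCOC1` gives 9880 nM. Compound 3 `COc1cc2ncnc(N3CCc4ccccc43)c2cc1NC(=O)/C=C/CN(C)C` gives 3370 nM, the lowest of the three numbers, although its gap to compound 1 stays within the usual scatter.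

Compound 2 arises from compound 1 by one change, (oxolan-3-yl in place of methyl on an oxygen on an aromatic ring), and this gave a 1.5-fold higher number from compound 1 to compound 2 (0.16 log units; within the scatter). Compound 3 arises from compound 1 by a different change, ((dimethylamino)methyl in place of isopropyl on a double-bonded chain carbon bound to a double-bonded chain carbon), which gave a 2.0-fold lower number from compound 1 to compound 3 (0.30 log units; within the scatter). The two cores of compound 3 and compound 4 therefore differ from the core of compound 1 in the way just described.

Compound 4 `CN(C)C/C=C/C(=O)Nc1cc2c(N3CCc4ccccc43)ncnc2cc1O[C@@H]1CCOC1` has not yet been measured. It differs from compound 3 by oxolan-3-yl in place of methyl on an oxygen on an aromatic ring. This is the same change that turns compound 1 into compound 2: the group that leaves, the group that enters and the place on the ring are described in exactly the same words for both pairs, so the change is the same, made on a core that carries the (dimethylamino)methyl-bearing chain rather than the isopropyl-bearing one.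

In this assay the expected step is a 1.5-fold higher number from compound 3 to compound 4 (0.17 log units; within the scatter), resting on the earlier outcome of the same change, which gave a 1.5-fold higher number from compound 1 to compound 2 (0.16 log units; within the scatter), a shift that stayed within scatter. Compound 4 is accordingly expected to give 5000 nM, with a likely range from 2500 nM to 10000 nM.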

Compound 4, half-maximal inhibitory concentration: 1340 nM
Beside the measured number, compound 4's estimate is 3.7-fold (0.57 log units) above it; the whole stated range lies above it.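

In this assay, putting (oxolan-3-yl)oxy in place of methoxy did not behave the same way on the two cores: on the core with the (dimethylamino)methyl-bearing chain it gave a 2.5-fold lower number from compound 3 to compound 4 (0.40 log units; beyond the scatter), which sits apart from its earlier outcome on the isopropyl-bearing core: the same change on two cores in this assay, a 1.5-fold higher number (0.16 log units; within the scatter) from compound 1 to compound 2 and a 2.5-fold lower number (0.40 log units; beyond the scatter) from compound 3 to compound 4, 3.7-fold (0.56 log units) apart, beyond the scatter of two such steps. Seen from the other side, (dimethylamino)methyl in place of isopropyl gave a 7.4-fold lower number from compound 2 to compound 4 (0.87 log units; beyond the scatter) on the core carrying (oxolan-3-yl)oxy, and that step too differs from its earlier counterpart: the same change on two cores in this assay, a 2.0-fold lower number (0.30 log units; within the scatter) from compound 1 to compound 3 and a 7.4-fold lower number (0.87 log units; beyond the scatter) from compound 2 to compound 4, 3.7-fold (0.56 log units) apart, beyond the scatter of two such steps. Both comparisons rest on the same set of compounds 1 to 4, so together they make a single observation that the outcome of each change depended on the group at the other place, and they show neither why that happened nor whether it would hold on any further core.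

The compounds shown leave open whether a smaller ring ether such as oxetan-3-yl, or an open chain such as 2-methoxyethyl, would follow compound 4 or compound 2 when set on that oxygen. They also leave open whether a ring amine such as morpholine or piperidine, in place of the dimethylamino group, would give a similar result.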